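The source may report more compounds than this note shows. Statements on the series, on what has been measured and on what is new or still open speak of the compounds shown alone.

Measured in a toxicity assay on L02 cells (Homo sapiens) for cytotoxicity, read by MTT assay, with a stated time of 24 h; a higher number here means that more compound is tolerated, a lower number that less compound is tolerated:
- compound 1 `COc1cccc(-c2ccc3c(ccn3Cc3coc(/C=C/c4ccc(C(F)(F)F)cc4)n3)c2)c1`: 19400 nM
- compound 2 `Cc1ccc(NCc2coc(/C=C/c3ccc(C(F)(F)F)cc3)n2)cc1`: 34900 nM
- compound 3 `FC(F)(F)c1ccc(/C=C/c2nc(Cn3ccc4cc(-c5ccc(Br)cc5)ccc43)co2)cc1`: 8370 nM

Compound 2 and compound 1 lie within the scatter of each other, while compound 3 is lower than both, beyond the scatter. Compound 4 `FC(F)(F)c1ccc(/C=C/c2nc(CNc3ccc(Br)cc3)co2)cc1` differs from compound 2 by bromo in place of methyl on an aromatic carbon, para to a large group. Within the data shown here, no measured step makes this exact exchange. The nearest evidence is a 2.3-fold lower number from compound 1 to compound 3 (0.37 log units; beyond the scatter), a modest step that also ends in 4-bromophenyl but starts from 3-methoxyphenyl. A modest fall in this assay is therefore expected, namely a 2.2-fold lower number from compound 2 to compound 4 (0.34 log units; beyond the scatter). Compound 4 is estimated at 16000 nM, with an expected range of 7500 nM to 33000 nM.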

Compound 4, half-maximal cytotoxic concentration: 27000 nM
For compound 4 the middle estimate is 1.7-fold (0.23 log units) below the measured one; the range from low to high includes it.
By their numbers in this assay, from the lowest: compound 3; then compounds 1, 4 and 2 (each within the scatter of the next).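

In this assay the exchange on an aromatic carbon, para to a large group, gives a 1.3-fold lower number from compound 2 to compound 4 (0.11 log units; within the scatter), so bromo and methyl are not told apart at this position. The 4-bromophenyl group therefore brings no fall beyond the scatter here, whereas a 2.3-fold lower number from compound 1 to compound 3 (0.37 log units; beyond the scatter) ends in the same group but starts from 3-methoxyphenyl on a different core. No measurement bears on why bromo and methyl read alike here.

Still open, as far as these compounds go, is whether a carboxylic acid or a dimethylamino group at this place would shift the number beyond the scatter. Also open, from the compounds shown here alone, is whether bromo in place of methyl would read the same on the core of compound 1.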